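This account rests on a few compounds, and the source may have more. Where it says the series, first, only, none or still open, it means among the compounds named here.

Within the data shown here, compound 1 `O=C([C@H]1Cc2cc(Cl)cc(-c3ccnc4cc(CO)sc34)c2O1)N1CCNCC1` is one of two compounds with a value so far. In an assay on isolated protein for inhibition of ubiquitin carboxyl-terminal hydrolase 47 (Homo sapiens) (on this read-out lower numbers stand for stronger inhibition and higher numbers for weaker inhibition), compound 1 gives > 40000 nM, which is a limit of the assay rather than a number. Compound 2 `O=C(C1Cc2cc(Cl)cc(-c3ccnc4[nH]ccc34)c2O1)N1CCNCC1` shares the halogenated bicyclic core and the piperazine amide but carries a different fused heteroaromatic substituent. In this assay compound 2 gives > 80000 nM, again only a limit. Compound 1 thus stands at the limit of > 40000 nM in this assay, at which 1 of the 2 values shown sits, and compound 2 at the limit of > 80000 nM in this assay, at which 1 of the 2 values shown sits, so neither offers a number to rank against.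

Compound 3 `O=C([C@H]1Cc2cc(Cl)cc(-c3ccnc4cc(Cn5cnccc5=O)sc34)c2O1)N1CCNCC1` differs from compound 1 by a group of 7 heavy atoms (4 carbon, 2 nitrogen, 1 oxygen; one six-membered aromatic ring with 2 hetero atoms) in place of one oxygen atom, on a saturated chain carbon bound to an aromatic carbon. Among the measured compounds shown here, no step between measured compounds is available, so the size of this change cannot be read from the data. Compound 3 is expected to remain at or near the limit, with the step from compound 1 to compound 3 estimated as a number no higher from compound 1 to compound 3 (the limit leaves the size open). For compound 3 the estimate in this assay is 40000 nM, within a range from 5000 nM to 100000 nM.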

Compound 3, half-maximal inhibitory concentration: > 5000 nM
Compound 3: a limit, no number (the forecaster's own chance of this, stated with the estimate: 70%); the middle value lies beyond the limit too.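

Compound 1 and compound 3 both stand only at limits in this assay, and the step between them cannot be read. The compounds shown leave open how strongly any of them inhibits, and whether exchanging the hydroxy for the group in compound 3 changes inhibition at all.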